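Swapping the sulfonamide substituent in a receptor antagonist series

A few compounds are considered here, and "the series" means these few. Any claim that something is new, unique, unknown or untested is made for them only; others in the source may bear on it.

Measured compounds:
- compound 1, `O=C(O)COc1ccc(Cl)cc1C#Cc1cccc(C(F)(F)F)c1`, 92 nM
- compound 2, `COCCNS(=O)(=O)c1ccc(C)c(C#Cc2cc(Cl)ccc2OCC(=O)O)c1`, 3.6 nM

Both compounds were tested in an assay on CHO cells for displacement of a labelled ligand from prostaglandin D2 receptor 2 (Homo sapiens), read by scintillation counting; on this read-out lower numbers stand for stronger inhibition and higher numbers for weaker inhibition. On this read-out compound 2, with 3.6 nM, stands at the lowest of the two numbers; compound 1, with 92 nM, sits far higher, a gap well beyond the usual scatter. For the measured compounds named here, the two compounds differ in more than one place, so the two values show only that compound 2 is the stronger of the pair, not which part of the structure is responsible.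

Compound 3, `Cc1ccc(S(=O)(=O)N(C)CCN(C)C)cc1C#Cc1cc(Cl)ccc1OCC(=O)O`, has not yet been measured in this assay. It keeps the core of compound 2 and changes only the group on the sulfonyl sulfur: (2-(dimethylamino)ethyl)(methyl)amino in place of (2-methoxyethyl)amino on a sulfonyl sulfur. Going by the values given here, no measured pair shows what such a change does here. From compound 2 to compound 3 a modest weakening is expected, a 2.2-fold higher number from compound 2 to compound 3 (0.35 log units; beyond the scatter), a step that may stay within the scatter. The expected value for compound 3 in this assay is 8 nM, with a range from 2 nM to 40 nM.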

Compound 3, inhibition constant: 369 nM
For compound 3 the middle estimate is 46-fold (1.66 log units) below the measured one; measured number above the stated range.
By their numbers in this assay, from the lowest: compound 2; then compound 1; then compound 3.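

In this assay, the group on the sulfonyl sulfur proves to be far from a free choice: putting (2-(dimethylamino)ethyl)(methyl)amino in place of (2-methoxyethyl)amino gives a 100-fold higher number from compound 2 to compound 3 (2.01 log units; beyond the scatter), and the rest of the molecule stays the same. This single-place step is a large one, well beyond the scatter, and it shows that binding in this series can depend heavily on what sits at this position. The step bundles several differences, as the entering group has no hydrogen-bond donor where the leaving group has one, carries a second nitrogen where the leaving group has an oxygen, and is larger, with 7 heavy atoms against 5, but nothing shown here gives a measured reason for the weakening.

The compounds shown leave open which of these differences accounts for the weakening, as they all arrive together in one step. A (2-(dimethylamino)ethyl)amino group or a (2-methoxyethyl)(methyl)amino group on the same sulfonyl sulfur would pull them apart, changing one feature at a time.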